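The compounds below may be only part of what the source reports. "The series", "measured", "known", "first", "only" and "open" are said of these compounds alone.

Compound 1 `Cc1cc(-c2c(C)nn(C)c2C)ccc1-c1nnc(N(C)Cc2ccc3nccn3c2)o1` gives > 31600 nM. Compound 2 `Cc1cc(-c2c(C)nn(C)c2C)cnc1-c1nnc(N(C)Cc2ccc3nccn3c2)o1` gives > 31600 nM. Compound 3 `Cc1cc(-c2c(C)nn(C)c2C)ccc1-c1nnc(N(C)Cc2ccc3ncc(-c4ccccc4)n3c2)o1` gives 20000 nM.

All three were tested in an assay on COS-7 cells for inhibition of tyrosine-protein kinase receptor TYRO3 (Homo sapiens), read by ELISA, with a stated time of 1 h; on this read-out higher numbers stand for weaker inhibition and lower numbers for stronger inhibition. For compound 1 the value > 31600 nM is a limit of the assay and not a number. For compound 2 the value > 31600 nM is likewise a limit. Compound 3, with 20000 nM in this assay, is the only one of the three that returns a number; the other two values sit at the limit of > 31600 nM in this assay, at which 2 of the 3 values shown sit. Among the compounds with values here, the single step that can be described is an at least 1.5-fold lower number from compound 1 to compound 3 (0.19 log units; that floor lies within the scatter), and its size is a floor that lies within the scatter.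

Compound 4 `Cc1cc(-c2c(C)nn(C)c2C)ccc1-c1nnc(N(C)Cc2ccc3ncc(-c4cnn(C)c4)n3c2)o1` carries 1-methyl-1H-pyrazol-4-yl in place of phenyl on an aromatic carbon. Within the data shown here, no measured step bears on this exchange directly; the only step at that position, an at least 1.5-fold lower number from compound 1 to compound 3 (0.19 log units; that floor lies within the scatter), compares phenyl with hydrogen and is small. Compound 4 is therefore expected to show no step beyond the scatter, no change at the digits printed from compound 3 to compound 4 (within the scatter), so its half-maximal inhibitory concentration in this assay is estimated at 20000 nM, within 8000 nM to 50000 nM.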

Compound 4, half-maximal inhibitory concentration: 12600 nM
For compound 4 the middle estimate is 1.6-fold (0.20 log units) above the measured one; the range from low to high includes it.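

In this assay, 1-methyl-1H-pyrazol-4-yl in place of phenyl on this aromatic carbon gives a 1.6-fold lower number from compound 3 to compound 4 (0.20 log units; within the scatter), so the two aromatic rings, one of carbon only and one with 2 hetero atoms, are not told apart here. Against hydrogen, where phenyl showed only a floor within the scatter, the new group gives an at least 2.5-fold lower number from compound 1 to compound 4 (0.39 log units; beyond the scatter), the first step at this position to pass beyond the scatter. That size is also only a floor, and the true step cannot be read for this reason: the limit of > 31600 nM in this assay, at which 2 of the 4 values shown sit.

The compounds shown leave open whether an amine, a carboxylic acid or a longer chain on this carbon would keep or lose this activity. They also leave open whether 1-methyl-1H-pyrazol-4-yl has a similar effect on the core of compound 2.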